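Swapping a Phenyl Ring and What It Costs in Cell Toxicity

A few compounds are considered here, and "the series" means these few. Any claim that something is new, unique, unknown or untested is made for them only; others in the source may bear on it.

Three compounds sharing a core were tested in an ADME assay on RAW264.7 cells (Mus musculus) for cytotoxicity, read by MTT assay, with a stated time of 24 h; on this read-out higher numbers stand for lower toxicity in this test and lower numbers for higher toxicity in this test. Compound 1 `Cc1ccc(C2=NN(C3=NC(=O)CS3)C(c3cccc(Cl)c3)C2)cc1C` gives 178000 nM. Compound 2 `COc1ccc(C2CC(c3ccc(C)c(C)c3)=NN2C2=NC(=O)CS2)cc1` differs from compound 1 by 4-methoxyphenyl in place of 3-chlorophenyl on a saturated ring carbon; compound 2 gives 387000 nM, so that a 2.2-fold higher number from compound 1 to compound 2 (0.34 log units; beyond the scatter). Compound 3 `O=C1CSC(N2N=C(c3ccc(Cl)c(Cl)c3)CC2c2cccc(Cl)c2)=N1` differs from compound 1 by 3,4-dichlorophenyl in place of 3,4-dimethylphenyl on a carbon with a double bond to nitrogen; compound 3 gives 165000 nM, with a 1.1-fold lower number from compound 1 to compound 3 (0.03 log units; within the scatter). Compound 4 `COc1ccc(C2CC(c3ccc(Cl)c(Cl)c3)=NN2C2=NC(=O)CS2)cc1` has not yet been measured in this assay. It differs from compound 3 by 4-methoxyphenyl in place of 3-chlorophenyl on a saturated ring carbon. Among the compounds with values here, this is the same kind of change as the one from compound 1 to compound 2, though the surroundings are not identical: in compound 3 the ring atom two ring bonds away bears a 3,4-dichlorophenyl group, whereas in compound 1 it bears a 3,4-dimethylphenyl group. The two cores give numbers within the usual scatter of each other, as a 1.1-fold lower number from compound 1 to compound 3 (0.03 log units; within the scatter) shows, so the step from compound 3 to compound 4 is expected to resemble the earlier one, roughly a 2.2-fold higher number from compound 3 to compound 4 (0.34 log units; beyond the scatter). Compound 4 is therefore expected to give about 360000 nM in this assay, most likely between 190000 nM and 700000 nM.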

Compound 4, half-maximal cytotoxic concentration: 264000 nM
For compound 4 the middle estimate is 1.4-fold (0.13 log units) above the measured one, within the range that was stated.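

In this assay, putting 4-methoxyphenyl in place of 3-chlorophenyl on the core that carries 3,4-dichlorophenyl gives a 1.6-fold higher number from compound 3 to compound 4 (0.20 log units; within the scatter), and the two steps for this change do not differ beyond what repeat measurements would allow: the same change on two cores in this assay, a 2.2-fold higher number (0.34 log units; beyond the scatter) from compound 1 to compound 2 and a 1.6-fold higher number (0.20 log units; within the scatter) from compound 3 to compound 4, 1.4-fold (0.13 log units) apart, within the scatter of two such steps

The other change, 3,4-dichlorophenyl in place of 3,4-dimethylphenyl, gives a 1.5-fold lower number from compound 2 to compound 4 (0.17 log units; within the scatter), and it too agrees across the two cores: the same change on two cores in this assay, a 1.1-fold lower number (0.03 log units; within the scatter) from compound 1 to compound 3 and a 1.5-fold lower number (0.17 log units; within the scatter) from compound 2 to compound 4, 1.4-fold (0.13 log units) apart, within the scatter of two such steps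

So in these four compounds each change carried over from one core to the other, but each comparison rests on a single pair of steps, and since the newer step for the 4-methoxyphenyl change lies within the scatter, this does not establish a real effect of that change on the second core, nor that agreement would hold on any further core.

The compounds shown leave open how a carboxylic acid or an amine would behave in place of the 4-methoxyphenyl group. They also leave open whether a longer chain on the oxygen of that group would fit the same picture.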